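Notes on the side-group swap leading to compound 4

This account rests on a few compounds, and the source may have more. Where it says the series, first, only, none or still open, it means among the compounds named here.

Compound 3 `CC(C(=O)NCc1ccc(C(F)(F)F)nc1C1CC2CCC1C2)c1ccc(NS(C)(=O)=O)c(F)c1` gives 1.5 nM in an assay on CHO cells for antagonist activity at transient receptor potential cation channel subfamily V member 1 (Homo sapiens), read by FLIPR and calcium flux; on this read-out lower numbers stand for stronger inhibition and higher numbers for weaker inhibition. Compound 2 `CC(C(=O)NCc1ccc(C(F)(F)F)nc1C1CCC(F)(F)CC1)c1ccc(NS(C)(=O)=O)c(F)c1` gives 1.5 nM in this assay, and compound 1 `CCCCCc1nc(C(F)(F)F)ccc1CNC(=O)C(C)c1ccc(NS(C)(=O)=O)c(F)c1` gives 1 nM. The step of a 1.5-fold higher number from compound 1 to compound 2 (0.18 log units; within the scatter) and the step of a 1.5-fold higher number from compound 1 to compound 3 (0.18 log units; within the scatter) both stay within the scatter, as does the step of no change at the digits printed from compound 2 to compound 3 (within the scatter), so the three numbers sit together and compound 3 stands level with compound 2 at the top of the three, with compound 1 the furthest away.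

Compound 4 `CCC1CC=C(c2nc(C(F)(F)F)ccc2CNC(=O)C(C)c2ccc(NS(C)(=O)=O)c(F)c2)CC1` differs from compound 3 by a group of 8 heavy atoms (8 carbon; one six-membered non-aromatic ring of carbon only) in place of a group of 7 heavy atoms (7 carbon; 2 five-membered non-aromatic rings of carbon only), on an aromatic carbon. The change sits on an aromatic carbon of a six-membered aromatic ring with 1 nitrogen, next to the ring nitrogen, ortho to a large group and meta to a trifluoromethyl group. All three measured steps bear on it, since each exchanges a carbon-rich group on that same aromatic carbon, and none of them moved the number beyond the scatter. The step from compound 3 to compound 4 is therefore expected to be no change at the digits printed from compound 3 to compound 4 (within the scatter), with no direction to call beyond the scatter. Compound 4 is estimated at 1.5 nM, with the range 0.6 nM to 4 nM.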

Compound 4, inhibition constant: 0.1 nM
Compound 4: middle estimate off by 15-fold (1.18 log units), on the high side; the whole stated range lies above it.
By their numbers in this assay, from the lowest: compound 4; then compounds 1, 2 and 3 (each within the scatter of the next).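

In this assay, 4-ethylcyclohex-1-en-1-yl on this aromatic carbon gives a 15-fold lower number from compound 3 to compound 4 (1.18 log units; beyond the scatter), a 15-fold lower number from compound 2 to compound 4 (1.18 log units; beyond the scatter) and a 10-fold lower number from compound 1 to compound 4 (1.00 log units; beyond the scatter). The earlier exchanges among pentyl, 4,4-difluorocyclohexyl and the group of 7 heavy atoms with two five-membered rings all stayed within the scatter, so this position looked insensitive to the group it carries; compound 4 now shows that the number can move well beyond the scatter through a change at this same carbon, and it stands as the most potent of the four compounds. Nothing available on these compounds accounts for the gain.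

The compounds shown do not separate the contribution of the ring double bond from that of the ethyl group, which the saturated 4-ethylcyclohexyl group and the plain cyclohex-1-en-1-yl group would each help to resolve. Going by these compounds, whether the gain persists with a longer chain such as butyl in place of the ethyl group, or with an amine or a carboxylic acid on that ring, also remains open.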